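From Benzyl to 4-Chlorophenyl on an Ether Tail

The source may hold more compounds than are shown below. What is called first, only, known or untested is meant among the compounds shown, and "the series" means these compounds.

Compound 1 `Cn1c(=O)[nH]c2ccc(OCCc3cccc(Cl)c3)cc21`: 13.7%
Compound 2 `Cn1c(=O)[nH]c2ccc(OCCCc3ccccc3)cc21`: 14%

In an assay on cells for inhibition of Amine oxidase [flavin-containing] B (Homo sapiens), read by fluorescence, with stated times of 30 min and 15 min, tested at 1 uM (a lower number here means less inhibition, a higher number more inhibition at the concentration tested (going by the name of the read-out)), compound 1 gives 13.7% and compound 2 gives 14%. Going by the values given here, compound 2 holds the higher of the two numbers, but its only neighbour sits within the scatter: a number 0.3 percentage points higher from compound 1 to compound 2 (within the scatter). Compound 3 `Cn1c(=O)[nH]c2ccc(OCCc3ccc(Cl)cc3)cc21` differs from compound 2 by 4-chlorophenyl in place of benzyl on a saturated chain carbon, two bonds along the chain from an oxygen on an aromatic ring. Among the compounds with values here, the one measured step that bears on this, a number 0.3 percentage points higher from compound 1 to compound 2 (within the scatter), traded 3-chlorophenyl for benzyl and stayed within the scatter, so a related swap of benzyl for a chlorine-bearing phenyl is expected to stay within the scatter as well: no change at the digits printed from compound 2 to compound 3 (within the scatter). Compound 3 is therefore estimated at 14%, between 5% and 25%.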

Compound 3, a percentage reported as inhibition, at one concentration (the size of the read-out at that concentration, not a potency): 19.9%
Compound 3: the middle estimate sits 5.9 percentage points below what was measured, within the range that was stated.
By their numbers in this assay, from the lowest: compounds 1, 2 and 3 (each within the scatter of the next).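

With 4-chlorophenyl in place of benzyl on this chain, the result is a number 5.9 percentage points higher from compound 2 to compound 3 (within the scatter), the largest listed number here but not a separate result. With 4-chlorophenyl in place of 3-chlorophenyl, it is a number 6.2 percentage points higher from compound 1 to compound 3 (within the scatter), so moving the chlorine around the ring has not yet produced a change that stands clear of ordinary repeat variation. Nothing available explains these numbers.

Still open, as far as these compounds go, is whether any group at this place can produce a step beyond the scatter. A 4-methoxyphenyl, a phenyl ring carrying an amine or a carboxylic acid, or a longer chain could test this.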